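The source may report more compounds than this note shows. Statements on the series, on what has been measured and on what is new or still open speak of the compounds shown alone.

Measured so far:
- compound 1 `COc1ccc(OC)c(N2C(=O)CSC2c2cccc(C(=O)NCCCCc3ccccc3)c2)c1`: 92%
- compound 2 `O=C(NCCCCc1ccccc1)c1cccc(C2OCC(=O)N2c2cccc(F)c2)c1`: 66%

Both numbers come from a functional assay on MG-63 cells (Homo sapiens) for inhibition, read by CCK-8 assay, with a stated time of 72 h, tested at 1 uM; on this read-out lower numbers stand for less inhibition and higher numbers for more inhibition at the one concentration tested (going by the name of the read-out). Compound 1 stands highest of the two, giving 92% in this assay. Within the data shown here, the only other measured member, compound 2, gives 66% in this assay; the gap between them lies beyond the usual scatter, and since the two structures differ in more than one place, nothing more than this comparison of values can be drawn from the pair.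

Compound 3 `Cc1cccc(N2C(=O)CSC2c2cccc(C(=O)NCCCCc3ccccc3)c2)c1` has not yet been measured. Relative to compound 1 the only change is 3-methylphenyl in place of 2,5-dimethoxyphenyl on an amide-type nitrogen in a ring. The group that enters is smaller and carries no hydrogen-bond acceptors, whereas the group that leaves carries two. Among the measured compounds shown here, no measured pair isolates a change at this position, so the direction of the step is open. A modest decrease in this assay is expected, quite possibly no larger than the scatter; the estimated step is a number 12 percentage points lower from compound 1 to compound 3 (beyond the scatter).

Compound 3 is therefore estimated at 80% in this assay, within a range of 58% to 95%.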

Compound 3, a percentage reported as inhibition, at one concentration (the size of the read-out at that concentration, not a potency): 93%
For compound 3 the middle estimate is 13 percentage points below the measured one; the range from low to high includes it.
By their numbers in this assay, from the lowest: compound 2; then compounds 1 and 3 (each within the scatter of the next).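

In this assay, among these compounds, the exchange of 2,5-dimethoxyphenyl for 3-methylphenyl on the amide-type nitrogen in a ring gives the first comparison that isolates a single place, and it reads as a number 1 percentage points higher from compound 1 to compound 3 (within the scatter). The entering group has 7 heavy atoms and 0 hydrogen-bond acceptors, against 10 heavy atoms and 2 hydrogen-bond acceptors in the leaving group, yet compound 3 gives 93%, so in this pair the two methoxy groups are not required for a high value at the one concentration tested. Nothing available explains why this exchange leaves the two values within the scatter of each other.

On these data alone, since both values are high and come from a single concentration, any difference in potency between compound 1 and compound 3 remains unresolved, and it is unknown whether a phenyl ring bearing a dimethylamino group or a carboxylic acid would hold the value at this position. Compound 2 differs from compound 3 in more than one place, so the separate contributions of its 3-fluorophenyl group and of the ring oxygen that stands where compound 3 has the ring sulfur cannot be read.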